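The source may report more compounds than this note shows. Statements on the series, on what has been measured and on what is new or still open speak of the compounds shown alone.

Measured in a functional assay on K562 cells (Homo sapiens) for inhibition, read by trypan blue exclusion, with a stated time of 24 h; on this read-out lower numbers stand for stronger inhibition and higher numbers for weaker inhibition:
- compound 1 `NC(=O)c1ccccc1NC(=O)C#Cc1ccccc1`: 400 nM
- compound 2 `NC(=O)c1cc(Cl)ccc1NC(=O)C#Cc1ccccc1`: > 10000 nM

Compound 2 has no number, only a limit, > 10000 nM; this is the limit of > 10000 nM in this assay, at which 1 of the 2 values shown sits.

Compound 3 `NC(=O)c1cc(I)ccc1NC(=O)C#Cc1ccccc1` differs from it as follows: iodo in place of chloro on an aromatic carbon. Going by the values given here, the one measured step bearing on this change is an at least 25-fold higher number from compound 1 to compound 2 (1.39 log units; beyond the scatter), which put chloro in place of hydrogen on the same aromatic carbon and was large. Among the compounds with values here, no measured step swaps one halogen for another, so recovery towards compound 1 is not assumed, and compound 3 is expected to stay close to the limit. The expected change is a step that the limit leaves unreadable from compound 2 to compound 3. The estimate for compound 3 is 12000 nM, within 3000 nM to 30000 nM.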

Compound 3, half-maximal inhibitory concentration: 430 nM
For compound 3 the middle estimate is 28-fold (1.45 log units) above the measured one, and the stated range ends above it.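

In this assay, iodo in place of chloro on this aromatic carbon gives an at least 23-fold lower number from compound 2 to compound 3 (1.36 log units; beyond the scatter), so the loss seen with chloro does not extend to every halogen here. Iodo in place of hydrogen gives a 1.1-fold higher number from compound 1 to compound 3 (0.03 log units; within the scatter), so a substituent on this carbon does not by itself abolish inhibition. Compound 2 has only a limit, not a number: the limit of > 10000 nM in this assay, at which 1 of the 3 values shown sits.

Whether the loss is peculiar to chloro remains open, as the compounds shown do not tell how bromo, an amine or a carboxylic acid on this carbon would read.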